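Dropping the Propargyl Group from a Weak Benzylamine

The source may hold more compounds than are shown below. What is called first, only, known or untested is meant among the compounds shown, and "the series" means these compounds.

Three measured compounds share one core. Compound 1 `C#CCNCc1cc2ccccc2n1C` gives 240 nM in an assay on isolated protein for inhibition of Amine oxidase [flavin-containing] A (Rattus norvegicus); a higher number here means a weaker inhibitor, a lower number a stronger inhibitor. Compound 3 `C#CCN(C)Cc1cc2ccccc2n1C` gives 0.3 nM in this assay. Compound 2 `C#CCN(Cc1ccccc1)Cc1cc2ccccc2n1C` gives 10000 nM, the highest of the three numbers; its nearest neighbour is compound 1, as a 42-fold higher number from compound 1 to compound 2 (1.62 log units; beyond the scatter) shows, and the furthest is compound 3, as a 33000-fold lower number from compound 2 to compound 3 (4.52 log units; beyond the scatter) shows. Compound 4 `Cn1c(CNCc2ccccc2)cc2ccccc21` differs from compound 2 by hydrogen in place of propargyl on an amine nitrogen. Going by the values given here, every measured compound keeps the propargyl group, so no measured step covers its removal; the steps of a 42-fold higher number from compound 1 to compound 2 (1.62 log units; beyond the scatter) and an 800-fold lower number from compound 1 to compound 3 (2.90 log units; beyond the scatter) show only that changes at this nitrogen move the number strongly in either direction. For compound 4 a weaker result is expected, a 5.0-fold higher number from compound 2 to compound 4 (0.70 log units; beyond the scatter), giving an estimated 50000 nM with a range from 5000 nM to 500000 nM.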

Compound 4, inhibition constant: 34000 nM
Beside the measured number, compound 4's estimate is 1.5-fold (0.17 log units) above it; the measured number falls inside the stated range.
By their numbers in this assay, from the lowest: compound 3; then compound 1; then compound 2; then compound 4.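

Taking the propargyl group off this amine nitrogen is the first measured step that covers the group, and with the benzyl group in place it changes the number only modestly (a 3.4-fold higher number from compound 2 to compound 4 (0.53 log units; beyond the scatter)). A far larger change comes from phenyl in place of ethynyl on the saturated chain carbon bound to the amine nitrogen (a 140-fold higher number from compound 1 to compound 4 (2.15 log units; beyond the scatter)). Nothing available explains either step. From the compounds shown here alone, whether removing propargyl costs as little when the nitrogen carries methyl, as in compound 3, stays open, as does the effect of an ethyl group on this nitrogen.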